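A Methyl Added to the Ethylsulfanyl Chain

The source may hold more compounds than are shown below. What is called first, only, known or untested is meant among the compounds shown, and "the series" means these compounds.

Compound 1 `CC1=C(C(=O)C2CC2)C(c2cccs2)NC(=O)N1`: 15%
Compound 2 `CCNC(=O)C1=C(C)NC(=O)NC1c1cccs1`: 4%
Compound 3 `CCSC(=O)C1=C(C)NC(=O)NC1c1cccs1`: 1%

All three were tested in an assay on membranes from HeLa cells for displacement of a labelled ligand from adenosine receptor A3 (Homo sapiens), read by scintillation counting, with a stated time of 180 min, tested at 1 uM; on this read-out lower numbers stand for less inhibition and higher numbers for more inhibition at the one concentration tested (going by the name of the read-out). For the measured compounds named here, compound 3 has the lowest of the three numbers, yet compound 2 sits within the scatter of it, so the two cannot be told apart; only the step of a number 14 percentage points lower from compound 1 to compound 3 (beyond the scatter) lies beyond the scatter. Compound 4 `CC1=C(C(=O)SC(C)C)C(c2cccs2)NC(=O)N1` differs from compound 3 by methyl in place of hydrogen on a saturated chain carbon bound to a saturated chain carbon and a sulfur. Going by the values given here, no measured step touches this chain: the steps of a number 11 percentage points lower from compound 1 to compound 2 (beyond the scatter) and a number 14 percentage points lower from compound 1 to compound 3 (beyond the scatter) exchange the whole group on the carbonyl carbon, and the step of a number 3 percentage points lower from compound 2 to compound 3 (within the scatter) stays within the scatter. The expectation is therefore no step beyond the scatter, a number 2 percentage points higher from compound 3 to compound 4 (within the scatter). Compound 4 is estimated at 3%, between -6% and 12%.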

Compound 4, a percentage reported as inhibition, at one concentration (the size of the read-out at that concentration, not a potency): 1%
Estimate against measurement, compound 4: 2 percentage points above; low and high end bracket the measured number.
By their numbers in this assay, from the lowest: compounds 3, 4 and 2 (each within the scatter of the next); then compound 1.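

For the compounds shown here, this is the first measured change on the chain itself, and the added methyl on this saturated chain carbon bound to a saturated chain carbon and a sulfur moves nothing (no change at the digits printed from compound 3 to compound 4 (within the scatter)). With isopropylsulfanyl on the carbonyl carbon, replacing ethylamino stays within the scatter (a number 3 percentage points lower from compound 2 to compound 4 (within the scatter)), while replacing cyclopropyl goes beyond it (a number 14 percentage points lower from compound 1 to compound 4 (beyond the scatter)), the same picture ethylsulfanyl gave. No measurement at hand offers an explanation for these numbers.

Still open, from the compounds shown here alone, is whether a longer chain, such as hexylsulfanyl, or a benzylsulfanyl group would change the read-out. Swapping cyclopropyl for phenyl on the carbonyl carbon also remains untested here.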